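A few compounds are considered here, and "the series" means these few. Any claim that something is new, unique, unknown or untested is made for them only; others in the source may bear on it.

Measured compounds in a functional assay on the whole organism with Rattus norvegicus as the target; a lower number here means that less compound is needed, a higher number that more compound is needed for the effect:
- compound 1 `CC(C)c1ccc2nc(N)sc2c1`: > 10 mg/kg.
- compound 2 `Nc1nc2ccc(OC(F)(F)C(F)F)cc2s1`: 8.5 mg/kg.
- compound 3 `C=CCn1c(=N)sc2cc(OC(F)(F)F)ccc21`: 7 mg/kg.

The entry of compound 1 is a limit of the assay, not a number, as the limit of > 10 mg/kg in this assay, at which 1 of the 3 values shown sits, records. Compound 2 and compound 3 each give a number; compound 3 has the lowest of the two, and the gap to compound 2 lies within the scatter, so no order between those two can be read from these values.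

The next compound, compound 4 `N=c1sc2cc(OC(F)(F)F)ccc2n1CCS`, has not yet been run in this assay. Compared with compound 3 it carries one change: sulfanylmethyl in place of vinyl on a saturated chain carbon bound to an aromatic nitrogen. The allyl becomes a 2-sulfanylethyl; the core and the trifluoromethoxy group are kept as in compound 3.

Within the data shown here, no pair of measured compounds differs at this position, so there is no measured step to lean on. The expectation is that the step of a 1.3-fold higher number from compound 3 to compound 4 (0.11 log units; within the scatter) stays small, of the size of the scatter or a little beyond it towards a higher number. On that basis compound 4 is estimated at 9 mg/kg, with a range of 3.5 mg/kg to 25 mg/kg, and a real chance that the assay returns only a limit.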

Compound 4, dose for half-maximal effect: 2 mg/kg
For compound 4 the middle estimate is 4.5-fold (0.65 log units) above the measured one, outside the stated range (below it).
By their numbers in this assay, from the lowest: compound 4; then compounds 3 and 2 (each within the scatter of the next). At a limit, above all of these: compound 1.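

In this assay, among these compounds, this is the first single change to give a step beyond the scatter: sulfanylmethyl in place of vinyl, on a saturated chain carbon bound to an aromatic nitrogen, gives a 3.5-fold lower number from compound 3 to compound 4 (0.54 log units; beyond the scatter) with the core and the trifluoromethoxy group kept. The position therefore responds to its substituent, and the 2-sulfanylethyl chain needs less compound for the effect than allyl. The entering group adds sulfur, one hydrogen-bond donor and one hydrogen-bond acceptor and loses the double bond, and nothing available ties the step to any one of these differences.

On these data alone, whether the sulfur is required remains open; a 2-hydroxyethyl or 2-aminoethyl group, or a longer chain ending in sulfanyl, would address this. Also open, as far as these compounds go, is whether the step carries over to a core bearing another group in place of trifluoromethoxy, as a single pair speaks for this position.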